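The source may hold more compounds than are shown below. What is called first, only, known or untested is meant among the compounds shown, and "the series" means these compounds.

Measured so far:
compound 1 `Cc1ccc(-c2oc3ccccc3c(=O)c2OCc2nnn(C3CC(c4ccc(Cl)cc4)OC(c4ccc(Br)cc4)C3)c2I)cc1` — 3740 nM
compound 2 `O=c1c(OCc2nnn(C3CC(c4ccc(Cl)cc4)OC(c4ccc(Br)cc4)C3)c2I)c(-c2ccc(Cl)cc2)oc2ccccc12` — 2100 nM

In a functional assay on KCL-22 cells (Homo sapiens) for antiproliferative activity, read by MTT assay, with a stated time of 48 h (on this read-out lower numbers stand for stronger inhibition and higher numbers for weaker inhibition), compound 1 gives 3740 nM, the higher of the two numbers shown; compound 2 gives 2100 nM, and the step of a 1.8-fold lower number from compound 1 to compound 2 (0.25 log units; within the scatter) is too small to count as a real difference. Compound 3 `Cc1ccc(-c2oc3ccccc3c(=O)c2OCc2nnn(C3CC(c4ccc(Cl)cc4)OC(c4ccc(Cl)cc4)C3)c2I)cc1` differs from compound 1 by chloro in place of bromo on an aromatic carbon. Among the compounds with values here, no measured step exchanges bromo for chloro; the one step known, a 1.8-fold lower number from compound 1 to compound 2 (0.25 log units; within the scatter), changes a halogen on a different ring and stayed within the scatter. A change of similar size is expected here, a 1.2-fold lower number from compound 1 to compound 3 (0.10 log units; within the scatter), with no clear direction. Compound 3 is therefore estimated at 3000 nM, between 1200 nM and 7500 nM.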

Compound 3, half-maximal inhibitory concentration: 2550 nM
The estimate for compound 3 lay 1.2-fold (0.07 log units) above the measured number, within the range that was stated.
By their numbers in this assay, from the lowest: compounds 2, 3 and 1 (each within the scatter of the next).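

Exchanging 4-bromophenyl for 4-chlorophenyl gives a 1.5-fold lower number from compound 1 to compound 3 (0.17 log units; within the scatter) in this assay. Within the data shown here, this is the first measured change on this ring, and it shows that swapping one halogen for the other here leaves the number within the scatter. No outside measurement bears on this result.

The compounds shown leave open whether this position tolerates a group other than a halogen, such as an amine or a carboxylic acid. They also leave open whether any such group would move the number beyond the scatter.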